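Moving a methyl around a phenyl ring in a cytotoxicity series

The source may report more compounds than this note shows. Statements on the series, on what has been measured and on what is new or still open speak of the compounds shown alone.

Three close analogues share one core, and each has been tested in an ADME assay on MT4 cells (Homo sapiens) for cytotoxicity, read by MTT assay, with a stated time of 4 days; a higher number here means that more compound is tolerated, a lower number that less compound is tolerated. Compound 1 `Cc1cc(C)cc(-c2cc(C)c(Nc3ccnc(Nc4ccc(C#N)cc4)n3)c(C)c2)c1` gives 4140 nM. Compound 2 `Cc1cc(-c2cc(Cl)cc(Cl)c2)cc(C)c1Nc1ccnc(Nc2ccc(C#N)cc2)n1` gives 4290 nM. Compound 3 `Cc1cccc(-c2cc(C)c(Nc3ccnc(Nc4ccc(C#N)cc4)n3)c(C)c2)c1` gives 3670 nM. Compound 3 stands level with its two neighbours: the step of a 1.1-fold lower number from compound 1 to compound 3 (0.05 log units; within the scatter) and the step of a 1.2-fold lower number from compound 2 to compound 3 (0.07 log units; within the scatter) both lie inside the scatter, as does a 1.0-fold higher number from compound 1 to compound 2 (0.02 log units; within the scatter), so nothing in this set separates one compound from another.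

Compound 4 `Cc1ccc(-c2cc(C)c(Nc3ccnc(Nc4ccc(C#N)cc4)n3)c(C)c2)cc1` differs from compound 3 only in the way the same atoms are joined: 4-methylphenyl in place of 3-methylphenyl on an aromatic carbon. For the measured compounds named here, no measured step shifts a methyl on this outer ring, but the closest comparisons, removing the methyl altogether or swapping the whole ring, left the number unchanged within scatter. The expectation for this assay is therefore no step beyond the scatter, that is a 1.0-fold higher number from compound 3 to compound 4 (0.02 log units; within the scatter). Compound 4 is expected to give 3800 nM, with a range from 2000 nM to 7500 nM.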

Compound 4, half-maximal cytotoxic concentration: 5570 nM
For compound 4 the middle estimate is 1.5-fold (0.17 log units) below the measured one; measured number inside the range.
By their numbers in this assay, from the lowest: compounds 3, 1, 2 and 4 (each within the scatter of the next).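

Shifting the methyl from the 3-methylphenyl of compound 3 to the 4-methylphenyl of compound 4 compares two arrangements of the same atoms on this outer ring, and in this assay it gives a 1.5-fold higher number from compound 3 to compound 4 (0.18 log units; within the scatter). The swaps from the dichlorinated and dimethylated rings read the same way, with a 1.3-fold higher number from compound 2 to compound 4 (0.11 log units; within the scatter) and a 1.3-fold higher number from compound 1 to compound 4 (0.13 log units; within the scatter), so no step among these four compounds leaves the scatter, whichever of these rings is attached. No measurement here speaks to what lies behind this sameness.

The rings shown carry only methyl or chlorine, so it remains open whether an amine, a carboxylic acid or a longer chain on this ring would give a step beyond the scatter. From the compounds shown here alone, it also remains open whether changes elsewhere on the shared core would read as flatly in this assay.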